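This account rests on a few compounds, and the source may have more. Where it says the series, first, only, none or still open, it means among the compounds named here.

Compound 1 `COc1cc(-c2ncnn2-c2ccccc2)cc(OC)c1OC` is the starting point of this comparison. In a functional assay on K562 cells (Homo sapiens) for antiproliferative activity, read by MTT assay, with a stated time of 72 h (on this read-out lower numbers stand for stronger inhibition and higher numbers for weaker inhibition), compound 1 gives > 10000 nM, which is a limit of the assay rather than a measured number. Compound 2 `COc1cc(-c2ncnn2-c2cccc([N+](=O)[O-])c2)cc(OC)c1OC` differs from compound 1 by a nitro in place of hydrogen on an aromatic carbon. In this assay compound 2 gives > 10000 nM, again only a limit. Because both ends sit at a limit, the step that the two limits leave unreadable from compound 1 to compound 2 cannot be sized. Compound 3 `CCOc1cccc(-c2ncnn2-c2cc(OC)c(OC)c(OC)c2)c1` is a third member of the set. In this assay compound 3 gives > 10000 nM, once more a limit. Where compound 1 stands is therefore only known as the limit of > 10000 nM in this assay, at which 3 of the 3 values shown sit, with nothing in the set that reaches a measured number.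

Compound 4 `COc1cc(-c2ncnn2-c2ccc(Cl)cc2)cc(OC)c1OC` has not yet been measured. Its change from compound 1 is chloro in place of hydrogen on an aromatic carbon. Among the measured compounds shown here, the only step between measured compounds, the one from compound 1 to compound 2, is unreadable, so it neither supports nor rules out a change in this assay for compound 4. With every measured value at the limit, compound 4 is expected to stay there as well. Compound 4 is estimated at 15000 nM, with a range from 5000 nM to 50000 nM. This corresponds to an expected step that the limit leaves unreadable from compound 1 to compound 4.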

Compound 4, half-maximal inhibitory concentration: > 10000 nM
Compound 4 was reported as a limit (the forecaster's own chance of this, stated with the estimate: 80%); the middle value does not contradict the limit.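

Compound 1 and compound 4 both sit at a limit of the assay, not at a measured number, and the change from phenyl to 4-chlorophenyl between them cannot be sized. The whole set gives the same picture: the limit of > 10000 nM in this assay, at which 4 of the 4 values shown sit. Left open is whether any change to the shared core would give a measured number in this assay.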